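Pyrazole enones: dichloro to difluoro on the benzoyl ring

The source may report more compounds than this note shows. Statements on the series, on what has been measured and on what is new or still open speak of the compounds shown alone.

Measured so far:
compound 1 `COc1ccc(-c2cc(/C=C/C(=O)c3ccc(N)cc3)[nH]n2)cc1` gives 2810 nM
compound 2 `COc1cc(-c2cc(/C=C/C(=O)c3ccc(Cl)c(Cl)c3)[nH]n2)cc(OC)c1OC` gives 8340 nM

Both compounds were run in a functional assay on TK-10 cells (Homo sapiens) for inhibition, read by sulforhodamine B assay, with a stated time of 48 h; on this read-out higher numbers stand for weaker inhibition of growth and lower numbers for stronger inhibition of growth. On the two numbers at hand, compound 2 stands at the highest; the nearest is compound 1, whose number is lower by a gap that lies beyond the scatter. No step between compounds that differ in only one place is available, so the two values are set side by side without a cause being assigned to the gap.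

The next compound is compound 3 `COc1cc(-c2cc(/C=C/C(=O)c3ccc(F)c(F)c3)[nH]n2)cc(OC)c1OC`. Relative to compound 2 the change is 3,4-difluorophenyl in place of 3,4-dichlorophenyl on a carbonyl carbon. Going by the values given here, nothing in the measured pair speaks directly to a halogen swap of this kind on the carbonyl-bound ring; the only comparison is between compound 1 and compound 2, which differ in several places at once. The expected step from compound 2 to compound 3 in this assay is therefore small, a 1.3-fold higher number from compound 2 to compound 3 (0.12 log units; within the scatter), and may well stay within the scatter. On that basis compound 3 is estimated at 11000 nM, with a range from 3500 nM to 35000 nM.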

Compound 3, concentration for 50% growth inhibition: 2290 nM
Compound 3: middle estimate off by 4.8-fold (0.68 log units), on the high side; measured number below the stated range.
By their numbers in this assay, from the lowest: compounds 3 and 1 (each within the scatter of the next); then compound 2.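

In this assay, going by these compounds alone, this is the first single-place change that can be read. The step is a 3.6-fold lower number from compound 2 to compound 3 (0.56 log units; beyond the scatter), so the carbonyl-bound ring is a place where the identity of the halogens alone moves the number beyond the scatter, with the 3,4-difluorophenyl compound giving the stronger inhibition of growth. The two groups match in heavy-atom count, aromatic ring and hydrogen-bond donors and acceptors, so those counts do not separate them, and nothing measured here accounts for the step.

A single pair cannot show whether the same swap gives a step of similar size on the core of compound 1, or whether the size of the halogen, its number or its placement on the ring is what tracks with the change. Also open, from the compounds shown here alone, is how a single fluorine, a trifluoromethyl group or a nitrile on this ring would compare with the 3,4-difluorophenyl group, and whether any such group would take the number further down or back up.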